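Swapping an acetyl for methylsulfanyl on a cyanoguanidine analogue

The source may hold more compounds than are shown below. What is called first, only, known or untested is meant among the compounds shown, and "the series" means these compounds.

Measured so far:
compound 1 `CC1(C)Oc2ccc(C#N)cc2[C@@H](NC(=O)Nc2cccnc2)[C@@H]1O`, 500 nM
compound 2 `CC(=O)c1cccc(N/C(=N/[C@@H]2c3cc(C#N)ccc3OC(C)(C)[C@H]2O)NC#N)c1`, 8400 nM

In a functional assay (aorta) with Rattus norvegicus as the target (on this read-out lower numbers stand for stronger inhibition and higher numbers for weaker inhibition), compound 2 gives 8400 nM, the highest of the two numbers; compound 1 gives 500 nM, a gap well beyond the scatter. Compound 3 `CSc1cccc(N/C(=N/[C@@H]2c3cc(C#N)ccc3OC(C)(C)[C@H]2O)NC#N)c1` keeps the shared core of compound 2 and differs only in one place: methylsulfanyl in place of acetyl on an aromatic carbon. Going by the values given here, no measured pair shows this exact change, so its effect is unknown. A small step from compound 2 to compound 3, a 1.4-fold lower number from compound 2 to compound 3 (0.15 log units; within the scatter), toward a lower number is expected, staying close to the scatter. Compound 3 is estimated at 6000 nM, within 1500 nM to 25000 nM.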

Compound 3, half-maximal inhibitory concentration: 1400 nM
Compound 3: middle estimate off by 4.3-fold (0.63 log units), on the high side, and the stated range ends above it.
By their numbers in this assay, from the lowest: compound 1; then compound 3; then compound 2.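

In this assay, putting methylsulfanyl in place of acetyl on this aromatic carbon, meta to a large group, gives a 6.0-fold lower number from compound 2 to compound 3 (0.78 log units; beyond the scatter). The group at this position therefore matters on this shared core, and a swap between these two small groups is enough to shift the read-out beyond the scatter. Nothing available explains why the change has this effect.

From the compounds shown here alone, with only these two groups compared here, it remains open how a methoxy group, an amine or a longer chain such as ethylsulfanyl would behave at this position. Going by these compounds, whether the same swap has a similar effect on another core also remains open.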